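This account rests on a few compounds, and the source may have more. Where it says the series, first, only, none or still open, it means among the compounds named here.

Measured so far:
compound 1 `CCCn1ccc2cc(-c3cccnc3)cc(Cl)c2c1=O` — 631 nM
compound 2 `CCCn1ccc2cc(-c3cncnc3)cc(Cl)c2c1=O` — 3980 nM

Among the measured compounds shown here, in a functional assay on CHO cells for agonist activity at metabotropic glutamate receptor 2 (Homo sapiens), read by GTPgammaS binding (a higher number here means that more compound is needed for the effect, a lower number that less compound is needed), compound 1 gives 631 nM, the lowest of the two numbers; the only other compound, compound 2, stands at 3980 nM, a step of a 6.3-fold higher number from compound 1 to compound 2 (0.80 log units; beyond the scatter). Compound 3 `CCCn1ccc2cc(-c3ccc(N(C)C)nc3)cc(Cl)c2c1=O` has not yet been measured. It differs from compound 1 by dimethylamino in place of hydrogen on an aromatic carbon. The one measured step concerns a different change, so no shown step bears directly on this one. Without a guide in the data, a number for compound 3 close to that of compound 1 is expected, with no step beyond the scatter: a 1.1-fold lower number from compound 1 to compound 3 (0.02 log units; within the scatter). Compound 3 is therefore estimated at 600 nM, with a range from 150 nM to 2500 nM.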

Compound 3, half-maximal effective concentration: 5010 nM
For compound 3 the middle estimate is 8.4-fold (0.92 log units) below the measured one; measured number outside the range, above it.
By their numbers in this assay, from the lowest: compound 1; then compounds 2 and 3 (each within the scatter of the next).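

Compound 1 carries only hydrogen on this aromatic carbon next to the ring nitrogen, and placing dimethylamino there gives a 7.9-fold higher number from compound 1 to compound 3 (0.90 log units; beyond the scatter) in this assay. So this position is not indifferent to change: with this group, more compound is needed for the effect. Nothing shown explains why this happens. From the compounds shown here alone, whether a single methyl, a methoxy or a plain amino group on the same carbon would shift the number as far remains open. So does the effect of a ring amine such as morpholine there.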